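Swapping the aryl group on a cyclopentane carbon

The source may report more compounds than this note shows. Statements on the series, on what has been measured and on what is new or still open speak of the compounds shown alone.

Compound 3 `CC(C)c1cccc(C(C)C)c1NC(=O)NCC1(c2cccc(N)c2)CCCC1` gives 21 nM in an assay on microsomes for inhibition of acyl-CoA:cholesterol acyltransferase (Oryctolagus cuniculus) (a lower number here means a stronger inhibitor, a higher number a weaker inhibitor), the lowest of the three numbers, though its neighbours lie within the scatter: compound 1 `CC(C)c1cccc(C(C)C)c1NC(=O)NCC1(c2ccc(F)cc2)CCCC1` gives 23 nM and compound 2 `CC(C)c1cccc(C(C)C)c1NC(=O)NCC1(c2ccc(Cl)cc2)CCCC1` gives 32 nM. Compound 4 `Cc1ccc(C2(CNC(=O)Nc3c(C(C)C)cccc3C(C)C)CCCC2)c(C)c1` differs from compound 3 by 2,4-dimethylphenyl in place of 3-aminophenyl on a saturated ring carbon. The comparable changes of the aryl group on the saturated ring carbon were small: a 1.1-fold lower number from compound 1 to compound 3 (0.04 log units; within the scatter) and a 1.5-fold lower number from compound 2 to compound 3 (0.18 log units; within the scatter), and the halogen swap a 1.4-fold higher number from compound 1 to compound 2 (0.14 log units; within the scatter) was also small. On that basis the step of a 1.2-fold higher number from compound 3 to compound 4 (0.08 log units; within the scatter) is expected to stay within the scatter. Compound 4 is therefore estimated to give 25 nM, with a range from 10 nM to 65 nM.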

Compound 4, half-maximal inhibitory concentration: 50 nM
Compound 4: middle estimate off by 2.0-fold (0.30 log units), on the low side; low and high end bracket the measured number.
By their numbers in this assay, from the lowest: compounds 3, 1, 2 and 4 (each within the scatter of the next, the first and the last beyond it).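

Here a change of the aryl group on the saturated ring carbon first moves the number in this assay beyond the scatter, with a 2.4-fold higher number from compound 3 to compound 4 (0.38 log units; beyond the scatter) and a 2.2-fold higher number from compound 1 to compound 4 (0.34 log units; beyond the scatter) both modest. The position is therefore not indifferent to the aryl group, yet a 1.6-fold higher number from compound 2 to compound 4 (0.19 log units; within the scatter) stays within the scatter, so 2,4-dimethylphenyl stands apart from only two of the three earlier groups. Nothing available explains this difference.

From the compounds shown here alone, it remains open which of the two methyl groups goes with the step, and how a phenyl carrying one methyl group, a methoxy group or a carboxylic acid would read.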